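Amine-bearing acrylamide tail on the crotonamide of compound 1

The compounds below may be only part of what the source reports. "The series", "measured", "known", "first", "only" and "open" are said of these compounds alone.

Compound 1 `C/C=C/C(=O)Nc1cc2c(N3CCCc4ccccc43)ncnc2cc1OC` gives 7520 nM in a functional assay on PC-3 cells (Homo sapiens) for antiproliferative activity, read by MTT assay, with a stated time of 72 h (a higher number here means a weaker inhibitor, a lower number a stronger inhibitor), the second highest of the three numbers. Its nearest neighbour is compound 2 `C/C=C/C(=O)Nc1cc2c(N3CCCc4ccccc43)ncnc2cc1O[C@@H]1CCOC1` with 9350 nM; the step of a 1.2-fold higher number from compound 1 to compound 2 (0.09 log units; within the scatter) is within the scatter. Furthest is compound 3 `COc1cc2ncnc(N3CCc4ccccc43)c2cc1NC(=O)/C=C/CN1CCCCC1` with 4180 nM, also within the scatter of compound 1, though compound 3 differs from compound 1 in two places, so no single step can be read from it. Compound 4 `COc1cc2ncnc(N3CCCc4ccccc43)c2cc1NC(=O)/C=C/CN1CCCC1` carries pyrrolidin-1-yl in place of hydrogen on a saturated chain carbon bound to a double-bonded chain carbon. For the measured compounds named here, no measured step isolates this change; compound 3, which carries a related amine on the same chain, shows only a within-scatter difference from compound 1. A step of at most scatter size, leaning lower, is therefore expected: a 1.5-fold lower number from compound 1 to compound 4 (0.18 log units; within the scatter). Compound 4 is estimated at 5000 nM, range 2000 nM to 12000 nM.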

Compound 4, half-maximal inhibitory concentration: 1740 nM
Beside the measured number, compound 4's estimate is 2.9-fold (0.46 log units) above it, outside the stated range (below it).
By their numbers in this assay, from the lowest: compound 4; then compounds 3, 1 and 2 (each within the scatter of the next, the first and the last beyond it).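

In this assay, for the compounds shown here, pyrrolidin-1-yl in place of hydrogen on a saturated chain carbon bound to a double-bonded chain carbon gives a 4.3-fold lower number from compound 1 to compound 4 (0.64 log units; beyond the scatter) and is the first single change beyond the scatter. The only earlier single change, oxolan-3-yl in place of methyl on an oxygen, stayed within it, so this chain carbon is the one place shown where a change moves the number. No measured evidence here explains the step.

Open, going by these compounds, is whether the pyrrolidine ring itself matters: dimethylamino or morpholin-4-yl on the same carbon would test this. Also open, on these data alone, is whether the step holds alongside oxolan-3-yl on the oxygen.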